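Methyl for hydrogen on the side chain: working notes

This account rests on a few compounds, and the source may have more. Where it says the series, first, only, none or still open, it means among the compounds named here.

Measured so far:
compound 1 `COc1ccc2nc(C(F)(F)F)cc(OCC(=O)Nc3cc(C)cc(C)c3)c2c1`: 15000 nM
compound 2 `CCOc1ccc2nc(C(F)(F)F)cc(OCC(=O)Nc3cc(C)cc(C)c3)c2c1`: a limit of the assay, < 1000 nM
compound 3 `COc1ccc2nc(C)cc(OC(C)C(=O)Nc3cc(C)cc(C)c3)c2c1`: 61000 nM

In a physicochemical assay for solubility, in phosphate buffer, measured as kinetic solubility, with a stated time of 1 h, at pH 7.4 (a lower number here means a less soluble compound, a higher number a more soluble compound), compound 1 gives 15000 nM. Compound 2 reaches only a limit of the assay, < 1000 nM (the limit of < 1000 nM in this assay, at which 1 of the 3 values shown sits). Compound 3 gives 61000 nM, the highest of the two numbers; the difference between the core of compound 3 and that of compound 1 is not broken down here.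

The change methyl in place of hydrogen on a saturated chain carbon bound to an oxygen on an aromatic ring gave an at least 15-fold lower number from compound 1 to compound 2 (1.17 log units; beyond the scatter).

Compound 4 `CCC(Oc1cc(C)nc2ccc(OC)cc12)C(=O)Nc1cc(C)cc(C)c1` carries the same kind of change against compound 3, (methyl in place of hydrogen on a saturated chain carbon, two bonds along the chain from a carbonyl carbon and an oxygen on an aromatic ring), though the place differs: here the carbon sits two bonds along the chain from a carbonyl carbon and an oxygen on an aromatic ring, not bound to that oxygen directly. A downward step is expected, a 7.6-fold lower number from compound 3 to compound 4 (0.88 log units; beyond the scatter), resting on an at least 15-fold lower number from compound 1 to compound 2 (1.17 log units; beyond the scatter). Compound 4 is expected near 8000 nM, between 1500 nM and 30000 nM.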

Compound 4, solubility: 123000 nM
Compound 4: the middle estimate sits 15-fold (1.19 log units) below what was measured; the measured number lies above the stated range.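

In this assay, methyl in place of hydrogen on a saturated chain carbon, two bonds along the chain from a carbonyl carbon and an oxygen on an aromatic ring, gave a 2.0-fold higher number from compound 3 to compound 4 (0.30 log units; within the scatter), so on this core the change shows no step beyond the scatter. The earlier at least 15-fold lower number from compound 1 to compound 2 (1.17 log units; beyond the scatter) did not carry over, but it lies on a different core and at a different place, on a saturated chain carbon bound to an oxygen on an aromatic ring, so these two steps cannot separate the effect of core from that of place. Compound 2 stands at a limit of the assay, not at a number: the limit of < 1000 nM in this assay, at which 1 of the 4 values shown sits.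

Going by these compounds, whether either change behaves the same way on the other core remains open. So does the outcome for propyl, an amine or a carboxylic acid at the chain carbon of compound 4.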